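Trifluoromethyl for methoxy on the aryl ring of compound 2

The source may hold more compounds than are shown below. What is called first, only, known or untested is meant among the compounds shown, and "the series" means these compounds.

Measured so far:
compound 1, `N#Cc1c(-c2ccccc2)c(C#N)c(=O)n(/N=C/c2cn(-c3ccccc3)nc2-c2ccccc2)c1N`, 180 ug/mL
compound 2, `COc1ccc(-c2c(C#N)c(N)n(/N=C/c3cn(-c4ccccc4)nc3-c3ccccc3)c(=O)c2C#N)cc1`, 50 ug/mL

The two measured compounds share one core and differ only in the aryl substituent on an aromatic carbon. In an ADME assay on NIH3T3 cells (Mus musculus) for cytotoxicity, read by MTT assay (on this read-out lower numbers stand for stronger inhibition and higher numbers for weaker inhibition), compound 1 gives 180 ug/mL, and compound 2 gives 50 ug/mL, the lower of the two numbers. Among the compounds with values here, the only measured step, a 3.6-fold lower number from compound 1 to compound 2 (0.56 log units; beyond the scatter), is a modest one and lies beyond the scatter.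

Compound 3, `N#Cc1c(-c2ccccc2C(F)(F)F)c(C#N)c(=O)n(/N=C/c2cn(-c3ccccc3)nc2-c2ccccc2)c1N`, has not yet been measured. It is made from compound 2 by 2-(trifluoromethyl)phenyl in place of 4-methoxyphenyl on an aromatic carbon. Within the data shown here, no measured step matches this change: the single step from compound 1 to compound 2 concerns a methoxy group put in place of hydrogen, whereas here the whole methoxy-bearing ring gives way to a ring carrying trifluoromethyl. The two measured values only show that the aryl substituent can move the number in this assay by a modest amount. Compound 3 is therefore expected to land between the two measured numbers, with a step of a 1.8-fold higher number from compound 2 to compound 3 (0.26 log units; within the scatter) and an estimated value of 90 ug/mL, in a range from 35 ug/mL to 250 ug/mL.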

Compound 3, half-maximal inhibitory concentration: 56 ug/mL
Compound 3: middle estimate off by 1.6-fold (0.21 log units), on the high side, and the stated range covers the measured number.
By their numbers in this assay, from the lowest: compounds 2 and 3 (each within the scatter of the next); then compound 1.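

In this assay, 2-(trifluoromethyl)phenyl in place of 4-methoxyphenyl on this aromatic carbon gives a 1.1-fold higher number from compound 2 to compound 3 (0.05 log units; within the scatter) and so leaves the number where it was, which shows that the oxygen of the 4-methoxyphenyl group is not needed for a value at this level. The comparison with the plain phenyl ring of compound 1 gives a 3.2-fold lower number from compound 1 to compound 3 (0.51 log units; beyond the scatter) and stands beside the earlier 3.6-fold lower number from compound 1 to compound 2 (0.56 log units; beyond the scatter) as a second step beyond the scatter, so a lower number at this position is no longer tied to methoxy alone, and neither substituted compound shown goes against this. Nothing available here explains why the two substituted rings read alike.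

The compounds shown leave open how far the group itself and its place on the ring each count, since 4-methoxyphenyl and 2-(trifluoromethyl)phenyl differ in both. They also leave open whether a phenyl ring carrying an amine, a carboxylic acid or a longer alkyl chain at this position would stay at this level in the same cytotoxicity read-out or move away from it.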